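Aryl substituent swap on the shared core: compound 1 to compound 4

The compounds below may be only part of what the source reports. "The series", "measured", "known", "first", "only" and "open" are said of these compounds alone.

Measured so far in a functional assay on K562 cells (Homo sapiens) for inhibition; on this read-out higher numbers stand for weaker inhibition and lower numbers for stronger inhibition:
compound 1 `CC(C)c1ccc(N2C(=O)C=CC2OCC(F)(F)F)cc1` — 6620 nM
compound 2 `O=C1C=CC(OCC(F)(F)F)N1c1cc(F)cc(F)c1` — 520 nM
compound 3 `O=C1C=CC(OCC(F)(F)F)N1c1ccc(F)c(Cl)c1` — 6320 nM

Compound 1 gives the highest number of the three. Its nearest neighbour is compound 3, whose value sits within the scatter of that of compound 1, so no order between those two can be read. Compound 2 stands well apart: its number is beyond the scatter below that of compound 1, and it is the only one of the three that differs from compound 1 in having two fluoro groups on the aryl ring rather than a single group at the position para to the large group.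

Compound 4 `O=C1C=CC(OCC(F)(F)F)N1c1ccc(Br)cc1` is not yet measured. It differs from compound 1 in one place: bromo in place of isopropyl on an aromatic carbon. Among the compounds with values here, the data hold no measured step that isolates this exchange. The two compounds that carry a single group at that position, compound 1 and compound 3, give numbers within the scatter of each other, which gives no sign that a change at this position moves the read-out much.

The expected step of a 1.5-fold lower number from compound 1 to compound 4 (0.17 log units; within the scatter) is therefore small, toward a somewhat lower number, and may fall within the scatter. Compound 4 is estimated at 4500 nM, with a range from 1500 nM to 13000 nM.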

Compound 4, half-maximal inhibitory concentration: 3270 nM
Compound 4: the middle estimate sits 1.4-fold (0.14 log units) above what was measured, within the range that was stated.
By their numbers in this assay, from the lowest: compound 2; then compounds 4, 3 and 1 (each within the scatter of the next, the first and the last beyond it).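

In this assay, within the data shown here, bromo in place of isopropyl on an aromatic carbon, para to a large group, gives a 2.0-fold lower number from compound 1 to compound 4 (0.31 log units; beyond the scatter), the first measured step that isolates a single change at this position. The step is modest and lies beyond the scatter, so the position is not silent: the read-out moves toward stronger inhibition when a group of three heavy atoms gives way to a single heavy atom. Nothing at hand bears on what lies behind this step, and with one exchange measured, it remains a single observation rather than a trend.

The compounds shown leave open how far the read-out moves with other groups on this carbon, such as a methoxy group, an amine or a carboxylic acid, and whether any of these would carry it further in the same direction or reverse it. Also open, on these data alone, is whether the exchange of isopropyl for bromo gives a step of similar size when other parts of the shared core are altered.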